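The source may hold more compounds than are shown below. What is called first, only, known or untested is meant among the compounds shown, and "the series" means these compounds.

Measured in an ADME assay on HeLa Rh cells (Homo sapiens) for cytotoxicity, read by microscopy (a lower number here means that less compound is tolerated, a higher number that more compound is tolerated), so far:
- Compound 1 `COc1ccc(-c2ccc(C(O)Cc3cc(OC)c(OC)cc3[N+](=O)[O-])cc2)cc1` gives > 244000 nM (a limit of the assay, not a number)
- Compound 2 `COc1cc(CC(O)c2ccc(-c3ccccc3C#N)cc2)c([N+](=O)[O-])cc1OC` gives 9300 nM
- Compound 3 `COc1cc(CC(O)c2ccc(-c3ccccc3[N+](=O)[O-])cc2)c([N+](=O)[O-])cc1OC` gives 9500 nM

Compound 3 stands level with compound 2, the step being a 1.0-fold higher number from compound 2 to compound 3 (0.01 log units; within the scatter). Both lie well under the limit reached by compound 1.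

Compound 4 `COc1cc(CC(O)c2ccc(-c3ccoc3)cc2)c([N+](=O)[O-])cc1OC` differs from compound 3 in one place: furan-3-yl in place of 2-nitrophenyl on an aromatic carbon. In words, this is furan-3-yl in place of 2-nitrophenyl on an aromatic carbon, para to a large group.

Two measured steps at this same place bear on the change. They are an at least 26-fold lower number from compound 1 to compound 2 (1.41 log units; beyond the scatter) and an at least 25-fold lower number from compound 1 to compound 3 (1.40 log units; beyond the scatter), both large. The group here can therefore move the number considerably, while nitro in place of cyano made no difference beyond the scatter. Among the compounds with values here, no measured compound carries a five-membered ring at this place, so the transfer is uncertain. Compound 4 loses the 2-nitrophenyl group and lacks 2-cyanophenyl too, so part of the way back towards compound 1 seems the likeliest outcome. The expected change is a 3.2-fold higher number from compound 3 to compound 4 (0.50 log units; beyond the scatter), a higher number but a smaller move than the two large steps. For compound 4 the estimate is 30000 nM, with an expected range of 8000 nM to 150000 nM.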

Compound 4, half-maximal cytotoxic concentration: 5300 nM
The estimate for compound 4 lay 5.7-fold (0.75 log units) above the measured number, outside the stated range (below it).
By their numbers in this assay, from the lowest: compounds 4, 2 and 3 (each within the scatter of the next). At a limit, above all of these: compound 1.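

In this assay, furan-3-yl at this place, on an aromatic carbon para to a large group, stands level with both substituted phenyl groups: a 1.8-fold lower number from compound 3 to compound 4 (0.25 log units; within the scatter), and a 1.8-fold lower number from compound 2 to compound 4 (0.24 log units; within the scatter). The number at this place therefore does not depend on a nitro or nitrile group, nor on a six-membered ring, since compound 4 carries none of these and still groups with compounds 2 and 3. Among the four compounds, only the 4-methoxyphenyl group of compound 1 stands apart, with an at least 46-fold lower number from compound 1 to compound 4 (1.66 log units; beyond the scatter), and that step is a bound set by a limit rather than a measured gap: the limit of > 244000 nM in this assay, at which 1 of the 4 values shown sits.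

From the compounds shown here alone, it remains open whether the separation of compound 1 belongs to the methoxy group itself or to the 4-substitution of its phenyl ring, a question that plain phenyl, 2-methoxyphenyl and 4-cyanophenyl at this place would address. Going by these compounds, it is also open whether the level seen with furan-3-yl extends to other groups here, such as thiophen-3-yl, a morpholine ring or a simple amine.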